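Aryl sulfone variation on the shared core

This account rests on a few compounds, and the source may have more. Where it says the series, first, only, none or still open, it means among the compounds named here.

Two compounds of the series carry numbers in an assay on isolated protein for displacement of a labelled ligand from metabotropic glutamate receptor 5 (Homo sapiens), with a stated time of 60 min, tested at 1 uM; on this read-out higher numbers stand for more inhibition at the one concentration tested (going by the name of the read-out) and lower numbers for less inhibition. Compound 1 `Cc1ccc(S(=O)(=O)c2cnc3cc(Cl)ccc3c2N2CCC(C)CC2)cc1F` gives 85% in this assay. For the measured compounds named here, compound 2 `CC1CCN(c2c(S(=O)(=O)c3ccc(F)c(Cl)c3)cnc3cc(Cl)ccc23)CC1` gives 94% in this assay; this is the higher of the two numbers, compound 1 being its only neighbour, and the gap between them lies within the scatter. Going by the values given here, the single measured step, a number 9 percentage points higher from compound 1 to compound 2 (within the scatter), exchanges the whole phenyl group on the sulfonyl sulfur and remains within the scatter.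

Compound 3 `COc1ccc(S(=O)(=O)c2cnc3cc(Cl)ccc3c2N2CCC(C)CC2)cc1Cl` is not yet measured. It differs from compound 2 as follows: methoxy in place of fluoro on an aromatic carbon. Among the compounds with values here, no measured step exchanges a methoxy for a fluoro, so the only guidance is the one step above, which alters the same phenyl group and stayed within the scatter. Within the scatter of the number of compound 2, compound 3 is expected to give about 88%, with a range from 70% to 98%. The expected step is a number 6 percentage points lower from compound 2 to compound 3 (within the scatter), with no direction beyond the scatter.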

Compound 3, a percentage reported as inhibition, at one concentration (the size of the read-out at that concentration, not a potency): 93%
Compound 3: middle estimate off by 5 percentage points, on the low side, and the stated range covers the measured number.
By their numbers in this assay, from the lowest: compounds 1, 3 and 2 (each within the scatter of the next).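

Going from 3-chloro-4-fluorophenyl to 3-chloro-4-methoxyphenyl gives a number 1 percentage points lower from compound 2 to compound 3 (within the scatter) in this assay, so this place, ortho to a chloro group and para to a large group, accepts a methoxy with its two heavy atoms and one hydrogen-bond acceptor as well as a fluoro on this read-out. The earlier step changed two substituents at once, whereas this one changes only the group at this place while the chloro stays; the wider exchange of 3-fluoro-4-methylphenyl for 3-chloro-4-methoxyphenyl on the sulfonyl sulfur gives a number 8 percentage points higher from compound 1 to compound 3 (within the scatter) and leaves all three phenyl groups shown within the scatter of one another. No measurement in hand bears on why these groups read alike.

With all three numbers this close at one concentration, the read-out gives no order among these compounds, and whether full concentration curves would separate them stays open. From the compounds shown here alone, it also stays open whether an amine, a carboxylic acid or a longer chain such as butoxy at this same place would keep the number at this level or move it beyond the scatter.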